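Swapping the nitro of compound 2 for hydrogen

The source may report more compounds than this note shows. Statements on the series, on what has been measured and on what is new or still open speak of the compounds shown alone.

Measured so far:
compound 1 `O=C(Nc1cccc([N+](=O)[O-])c1)c1cc(Cl)ccc1O` gives 3530 nM
compound 2 `O=C(Nc1ccc([N+](=O)[O-])c(Cl)c1)c1cc(Cl)ccc1O` gives 1510 nM

Among the measured compounds shown here, both numbers come from a toxicity assay on Vero C1008 cells (Chlorocebus sabaeus) for cytotoxicity, read by MTT assay, with a stated time of 48 h (a lower number here means that less compound is tolerated, a higher number that more compound is tolerated), and are the only measurements available. Compound 2 (1510 nM) has the lower number of the two, and its gap to compound 1 (3530 nM) lies beyond the usual scatter of repeated measurements.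

Compound 3 `O=C(Nc1cccc(Cl)c1)c1cc(Cl)ccc1O` differs from compound 2 at a single place (hydrogen in place of nitro on an aromatic carbon). There it has hydrogen in place of nitro on an aromatic carbon.

For the measured compounds named here, no measured pair shows this swap, so the direction is a judgement that leans on compound 1 (3530 nM) as the only nearby number. A moderate rise in this assay is expected, with more compound tolerated. The estimated change is a 2.3-fold higher number from compound 2 to compound 3 (0.37 log units; beyond the scatter) and could still fall within the scatter. For compound 3 the expected value is 3500 nM within an estimated range of 1100 nM to 11000 nM in this assay.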

Compound 3, half-maximal cytotoxic concentration in the Vero C1008 assay: 2460 nM
The estimate for compound 3 lay 1.4-fold (0.15 log units) above the measured number, within the range that was stated.
By their numbers in the Vero C1008 assay, from the lowest: compounds 2, 3 and 1 (each within the scatter of the next, the first and the last beyond it).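

In the Vero C1008 assay, hydrogen in place of nitro gives a 1.6-fold higher number from compound 2 to compound 3 (0.21 log units; within the scatter) and chloro in place of nitro gives a 1.4-fold lower number from compound 1 to compound 3 (0.16 log units; within the scatter) so neither swap gives any sign that the tolerated concentration depends on the nitro in these compounds. The picture differs in a physicochemical assay for solubility, read by HPLC (a lower number here means a less soluble compound, a higher number a more soluble compound), where the same change on the aromatic carbon ortho to a chloro group gives an at least 5.1-fold lower number from compound 2 to compound 3 (0.70 log units; beyond the scatter) and so separates the pair clearly. In the physicochemical assay compound 2 gives 5.1 ug/mL. In the physicochemical assay compound 3 gives < 1 ug/mL which is a limit of the assay and not a number: the limit of < 1 ug/mL in the physicochemical assay, at which 1 of the 2 values shown sits.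

These compounds leave open whether a different group at this position, such as an amine or a carboxylic acid, would shift either read-out. They also cannot tell how much lower the true solubility of compound 3 lies.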